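A Side-Group Exchange Followed in Vero Cell Cytotoxicity

A few compounds are considered here, and "the series" means these few. Any claim that something is new, unique, unknown or untested is made for them only; others in the source may bear on it.

Of the compounds shown here, two built on a shared core have so far been measured in an ADME assay on Vero cells (Chlorocebus sabaeus) for cytotoxicity, with a stated time of 7 days; on this read-out lower numbers stand for higher toxicity in this test and higher numbers for lower toxicity in this test. Compound 1 `COc1ccc2[nH]c(C(=O)N3CC(=O)N(Cc4ccccc4)[C@@H](CN4CCC5(CC4)CC5)C3)cc2c1` gives 17100 nM in this assay, which is the highest of the two numbers. Compound 2 `COc1ccc2[nH]c(C(=O)N3CC(=O)N(Cc4c[nH]c5ccccc45)[C@@H](Cc4ccccc4)C3)cc2c1` gives 7200 nM in this assay, a lower number whose gap to compound 1 lies beyond the usual scatter, so compound 2 appears the more toxic of the pair. Compound 2 differs from compound 1 in more than one place, so this pair says nothing about any single change.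

Compound 3 `COc1ccc2[nH]c(C(=O)N3CC(=O)N(Cc4ccccc4)[C@@H](CN4CCn5cccc5C4)C3)cc2c1` has not been measured yet. It differs from compound 1 at a single spot: a group of 9 heavy atoms (7 carbon, 2 nitrogen; one five-membered aromatic ring with 1 hetero atom, one six-membered non-aromatic ring with 2 hetero atoms) in place of a group of 8 heavy atoms (7 carbon, 1 nitrogen; one three-membered non-aromatic ring of carbon only, one six-membered non-aromatic ring with 1 hetero atom), on a saturated chain carbon bound to a saturated ring carbon. For the measured compounds named here, the leaving and entering groups are of similar size, and no measured pair shows what this kind of exchange does in this assay. Compound 3 is therefore expected to stay close to compound 1, with a step of a 1.2-fold lower number from compound 1 to compound 3 (0.09 log units; within the scatter) that is small and most likely within the scatter, leaning if anything toward a lower number. Compound 3 is estimated at 14000 nM, with a range from 6000 nM to 32000 nM.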

Compound 3, half-maximal cytotoxic concentration: > 100000 nM
Compound 3: no number, only a limit; the forecaster's own chance of this, stated with the estimate: 10%; middle value at least 7.1-fold (0.85 log units) away from the limit.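

In this assay, for the compounds shown here, this is the first exchange that can be read at a single place, on a saturated chain carbon bound to a saturated ring carbon, and it gives an at least 5.8-fold higher number from compound 1 to compound 3 (0.76 log units; beyond the scatter). The leaving and entering groups are of similar size, yet the step lies beyond the scatter, so this place in the shared core clearly bears on the read-out, with the higher number standing for lower toxicity in this test. The reading of compound 3 is a limit and not a number, so the step gives only a lower bound on the size of the change: the limit of > 100000 nM in this assay, at which 1 of the 3 values shown sits.

On these data alone, a single pair cannot separate the parts of the exchange, so it stays open whether the five-membered aromatic ring with 1 hetero atom, the six-membered non-aromatic ring with 2 hetero atoms, or the loss of the three-membered non-aromatic ring of carbon only goes with the higher number. The compounds shown also leave open how a morpholine or a simple dimethylamino group would read at this same place, and whether any such group would also reach the limit.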